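The compounds below may be only part of what the source reports. "The series", "measured", "known", "first", "only" and "open" are said of these compounds alone.

Measured in a functional assay on HEK293 cells for agonist activity at Vasopressin V2 receptor (Homo sapiens), read by a luciferase reporter and cAMP accumulation; on this read-out lower numbers stand for an effect already at smaller amounts and higher numbers for an effect only at larger amounts of compound:
compound 1 `O=C(NCc1ccc(C(=O)N2CCCCc3ccccc32)c(F)c1)Nc1c(F)cccc1F` gives 180 nM;
compound 2 `Cc1cc(C(=O)N2CCCCc3ccccc32)cc(C)c1CNC(=O)Nc1c(F)cccc1F` gives 82 nM;
compound 3 `Cc1cc(C(=O)N2CCCCc3ccccc32)ccc1CNC(=O)NCC(=O)N(C)C` gives 58 nM.

Compound 3 gives the lowest of the three numbers. Its gap to compound 2 lies within the scatter, so no order between these two can be read; its gap to compound 1 lies beyond the scatter. Compound 4 `Cc1cc(C(=O)N2CCCCc3ccccc32)ccc1CNC(=O)N1CCC[C@@H]1C(=O)N(C)C` differs from compound 3 in one place: 2-(dimethylcarbamoyl)pyrrolidin-1-yl in place of ((dimethylcarbamoyl)methyl)amino on a carbonyl carbon. Going by the values given here, no pair among the measured compounds shows the effect of such a change, so the direction is open. In this assay compound 4 is expected to come out close to compound 3, with the step from a 1.4-fold higher number from compound 3 to compound 4 (0.14 log units; within the scatter) estimated not to go clearly beyond the scatter in either direction. The estimate for compound 4 is 80 nM, in a range from 20 nM to 320 nM.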

Compound 4, half-maximal effective concentration: 380 nM
Beside the measured number, compound 4's estimate is 4.8-fold (0.68 log units) below it, and the stated range ends below it.
By their numbers in this assay, from the lowest: compounds 3 and 2 (each within the scatter of the next); then compound 1; then compound 4.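

This position on a carbonyl carbon does respond to the group it carries: 2-(dimethylcarbamoyl)pyrrolidin-1-yl in place of ((dimethylcarbamoyl)methyl)amino brings a 6.6-fold higher number from compound 3 to compound 4 (0.82 log units; beyond the scatter) in this assay. The change swaps a hydrogen-bond donor for a five-membered ring with a defined stereocentre, and this single pair cannot separate these features. No measurement here accounts for the step. Still open, as far as these compounds go, is how a methylamino group carrying the same dimethylcarbamoylmethyl chain, or the opposite stereocentre on the pyrrolidine, would read.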